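The source may report more compounds than this note shows. Statements on the series, on what has been measured and on what is new or still open speak of the compounds shown alone.

Compound 1 `C=C1[C@H](C)CCC[C@]1(C)CC/C(C)=C/CC1=C(O)C(=O)C=C(OC)C1=O`: 1.8 ug/mL in a functional assay on KB16 cells (Homo sapiens) for cytotoxicity, read by MTT assay; on this read-out higher numbers stand for weaker inhibition and lower numbers for stronger inhibition
Compound 2 `C=C1[C@H](C)CCC[C@]1(C)CC[C@@]1(C)C=Cc2c(O)c(OC)cc(OC)c2O1`: 0.68 ug/mL in this assay

Of these two, compound 2 stands at the lower number in this assay, and its gap to compound 1 is beyond the scatter. Compound 3 `C=C1[C@H](C)CCC[C@]1(C)CC[C@@]1(C)C=Cc2c(OC(C)=O)c(OC)cc(OC)c2O1` is not yet measured. It differs from compound 2 in one place only: acetyl in place of hydrogen on an oxygen on an aromatic ring. For the measured compounds named here, with no measured pair showing such a change, the step is expected to be small; for compound 3 the step of a 1.5-fold higher number from compound 2 to compound 3 (0.17 log units; within the scatter) is expected to lie within the scatter or a little toward a higher number. Compound 3 is therefore estimated at 1 ug/mL, in a range of 0.4 ug/mL to 2.5 ug/mL.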

Compound 3, half-maximal inhibitory concentration: 1.32 ug/mL
The estimate for compound 3 lay 1.3-fold (0.12 log units) below the measured number, within the range that was stated.
By their numbers in this assay, from the lowest: compounds 2, 3 and 1 (each within the scatter of the next, the first and the last beyond it).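

Putting acetyl in place of hydrogen on this oxygen on the aromatic ring gives a 1.9-fold higher number from compound 2 to compound 3 (0.29 log units; within the scatter) in this assay and so, in this pair, the hydroxy hydrogen can be replaced without a shift beyond the usual scatter. For the compounds shown here, this is the first sign that the position accepts a group larger than hydrogen. Nothing available explains why the two compounds read so alike. On these data alone, whether a longer acyl chain, such as benzoyl, would also stay within the scatter remains open. So does the effect of a group carrying an amine or a carboxylic acid at this oxygen.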